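Working notes: changing the nitrogen substituent of compound 2

A few compounds are considered here, and "the series" means these few. Any claim that something is new, unique, unknown or untested is made for them only; others in the source may bear on it.

- compound 1 `O=c1c2ccccc2c(-c2cccnc2)nn1Cc1ccccc1`: 2450 nM
- compound 2 `CCOC(=O)Cn1nc(-c2cccnc2)c2ccccc2c1=O`: 43700 nM

Within the data shown here, in a functional assay (trachea) with Cavia porcellus as the target (a lower number here means a stronger inhibitor, a higher number a weaker inhibitor), compound 2 holds the higher of the two numbers, and the only measured step, an 18-fold higher number from compound 1 to compound 2 (1.25 log units; beyond the scatter), is large and beyond the scatter. Compound 3 `O=C(c1cccs1)n1nc(-c2cccnc2)c2ccccc2c1=O` is still unmeasured. The change is (thiophen-2-yl)carbonyl in place of (ethoxycarbonyl)methyl on an aromatic nitrogen. The measured step bears on this only in part. Compound 1 carries phenyl where compound 2 carries ethoxycarbonyl, and an 18-fold higher number from compound 1 to compound 2 (1.25 log units; beyond the scatter) went upward on that exchange. Among the measured compounds shown here, compound 3 again has an aromatic ring, but no measured compound has a carbonyl on that nitrogen. A move down in this assay is therefore expected, of smaller size than the measured step. The estimated move is a 4.9-fold lower number from compound 2 to compound 3 (0.69 log units; beyond the scatter) in size. For compound 3 the estimate is 9000 nM, with an expected range from 1800 nM to 45000 nM.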

Compound 3, half-maximal inhibitory concentration: 12300 nM
The estimate for compound 3 lay 1.4-fold (0.14 log units) below the measured number; the range from low to high includes it.
By their numbers in this assay, from the lowest: compound 1; then compound 3; then compound 2.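

In this assay the substituent on the aromatic nitrogen need not be joined through a saturated chain carbon: (thiophen-2-yl)carbonyl in place of (ethoxycarbonyl)methyl gives a 3.6-fold lower number from compound 2 to compound 3 (0.55 log units; beyond the scatter) and so recovers part of the loss seen with the ester. The recovery is incomplete, as (thiophen-2-yl)carbonyl in place of benzyl gives a 5.0-fold higher number from compound 1 to compound 3 (0.70 log units; beyond the scatter) and an aromatic ring in the substituent does not by itself match benzyl, although among these three compounds both substituents with an aromatic ring hold lower numbers than the ester, and none goes against this. No data on hand account for this order.

These compounds do not separate the contribution of the carbonyl link from that of the thiophene ring; benzoyl or thiophen-2-ylmethyl on the same nitrogen would separate them. Also open, going by these compounds, is how a carboxylic acid or an amine at the end of a longer chain on that nitrogen would read in this assay against these values.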